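This account rests on a few compounds, and the source may have more. Where it says the series, first, only, none or still open, it means among the compounds named here.

Three compounds with a shared core, an imine link and a diaryl ether have been measured in a physicochemical assay for lipophilicity, in phosphate buffer, measured as octanol-water partition; a higher number here means a more lipophilic compound, a lower number a more polar compound. Compound 1 `O=c1c2ccccc2nc(-c2ccccc2)n1/N=C/c1ccc(Oc2ccc(Br)cc2)cc1` gives 6.39. Compound 2 `CCCc1nc2ccccc2c(=O)n1/N=C/c1ccc(Oc2ccc(Cl)c(C)c2)cc1` gives 6.02. Within the data shown here, compound 3 `O=c1c2ccccc2nc(-c2ccccc2)n1/N=C/c1ccc(Oc2ccc([N+](=O)[O-])cc2)cc1` gives 6.12, a number that lies within the scatter of both compound 2 and compound 1; the only single change among them, a number 0.27 log units lower from compound 1 to compound 3 (within the scatter), stayed within the scatter. Compound 4 `O=c1c2ccccc2nc(-c2ccccc2)n1/N=C/c1ccc(Oc2ccccc2)cc1` differs from compound 3 in one place: hydrogen in place of nitro on an aromatic carbon. That earlier step is the one that bears on this change, since it also touched the nitro group, and it was small; the step to compound 4 is therefore expected to be a number 0.18 log units higher from compound 3 to compound 4 (within the scatter), not beyond the scatter. Compound 4 is estimated at 6.3, between 5.9 and 6.7.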

Compound 4, partition coefficient: 6.13
Beside the measured number, compound 4's estimate is 0.17 log units above it; the measured number falls inside the stated range.
By their numbers in this assay, from the lowest: compounds 2, 3, 4 and 1 (each within the scatter of the next, the first and the last beyond it).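

In this assay, hydrogen on this aromatic carbon gives a number 0.01 log units higher from compound 3 to compound 4 (within the scatter) when it replaces nitro and a number 0.26 log units lower from compound 1 to compound 4 (within the scatter) when it replaces bromo. With the earlier step, nitro, bromo and hydrogen can now all be compared at this one place, and all three steps among them stay within the scatter. Nothing available here explains these small steps. From the compounds shown here alone, whether an amine, a carboxylic acid or a longer chain at this place would give a step beyond the scatter remains open. Also open, going by these compounds, is whether hydrogen in place of nitro would read the same on the core of compound 2.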